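Nitrile in Place of Fluorine on the Benzoyl Ring

The compounds below may be only part of what the source reports. "The series", "measured", "known", "first", "only" and "open" are said of these compounds alone.

Compound 1, `CC(C)(C)N(NC(=O)c1ccccc1Cl)C(=O)c1ccccc1Cl`: 331 nM
Compound 2, `Cc1ccccc1C(=O)NN(C(=O)c1ccccc1Cl)C(C)(C)C`: 72.4 nM
Compound 3, `CC(C)(C)N(NC(=O)c1cccc(F)c1)C(=O)c1ccccc1Cl`: 69.2 nM

Of the compounds shown here, three sharing one core have been tested in an assay on cells for agonist activity at ecdysone receptor (Bombyx mori), read by a luciferase reporter, with a stated time of 24 h; a lower number here means that less compound is needed, a higher number that more compound is needed for the effect. Compound 3 sits well clear of compound 1, as a 4.8-fold lower number from compound 1 to compound 3 (0.68 log units; beyond the scatter) shows, while its gap to compound 2, a 1.0-fold lower number from compound 2 to compound 3 (0.02 log units; within the scatter), lies within the scatter, so those two cannot be told apart. Compound 4, `CC(C)(C)N(NC(=O)c1cccc(C#N)c1)C(=O)c1ccccc1Cl`, carries the change (cyano in place of fluoro on an aromatic carbon). For the measured compounds named here, no measured step involves a cyano group; the two steps that alter the same benzoyl ring, a 4.6-fold lower number from compound 1 to compound 2 (0.66 log units; beyond the scatter) and a 4.8-fold lower number from compound 1 to compound 3 (0.68 log units; beyond the scatter), both start from compound 1 and say nothing about swapping one small substituent on compound 3 for another. The expected step is therefore a 1.1-fold higher number from compound 3 to compound 4 (0.03 log units; within the scatter), nothing beyond the scatter. Compound 4 is estimated at 75 nM, between 25 nM and 220 nM.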

Compound 4, half-maximal effective concentration: 955 nM
Beside the measured number, compound 4's estimate is 13-fold (1.10 log units) below it; the whole stated range lies below it.
By their numbers in this assay, from the lowest: compounds 3 and 2 (each within the scatter of the next); then compound 1; then compound 4.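

In this assay, for the compounds shown here, the group on this aromatic carbon matters far more than the earlier compounds could show: cyano in place of fluoro gives a 14-fold higher number from compound 3 to compound 4 (1.14 log units; beyond the scatter). The other two comparisons point the same way, with a 13-fold higher number from compound 2 to compound 4 (1.12 log units; beyond the scatter) and a 2.9-fold higher number from compound 1 to compound 4 (0.46 log units; beyond the scatter), so this single change more than cancels the advantage compound 3 held over compound 1. Nothing measured here explains the loss.

From the compounds shown here alone, whether other groups at this place, such as an amine, a methoxy or a carboxylic acid, would behave like fluoro or like cyano remains open. So does the effect of cyano on other carbons of this ring.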